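Swapping the Outer Aryl Group: Cytotoxicity Stays Out of Reach

The source may hold more compounds than are shown below. What is called first, only, known or untested is meant among the compounds shown, and "the series" means these compounds.

Compound 1 `CC(C)N(Cc1cccc(OCCCCCC(=O)O)c1)C(=O)c1ccc(-c2cccc3ccccc23)cc1` gives > 26000 nM in an ADME assay on HepG2 cells (Homo sapiens) for cytotoxicity, read by CellTiter-Glo and resazurin assay, with a stated time of 72 h; a lower number here means that less compound is needed, a higher number that more compound is needed for the effect; this is a limit of the assay, not a number.
Compound 2 `CC(C)N(Cc1cccc(OCCCCCC(=O)O)c1)C(=O)c1ccc(-c2ccsc2)cc1` gives > 26000 nM in this assay, again a limit.
Compound 3 `CC(C)N(Cc1cccc(OCCCCCC(=O)O)c1)C(=O)c1ccc(-c2cc3ccccc3n2S(=O)(=O)c2ccccc2)cc1` gives > 26000 nM in this assay, also a limit.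

Compound 2 thus stands at the same limit as the two other measured compounds, and nothing places it above or below them. All three values sit at the limit of > 26000 nM in this assay, at which 3 of the 3 values shown sit. For the measured compounds named here, the one measured step at the same position, a step that the two limits leave unreadable from compound 1 to compound 2, has no readable size. Compound 4 `CC(C)N(Cc1cccc(OCCCCCC(=O)O)c1)C(=O)c1ccc(-c2cccc(OC(F)(F)F)c2)cc1` differs from compound 2 in this way: 3-(trifluoromethoxy)phenyl in place of thiophen-3-yl on an aromatic carbon. With no readable step to build on, no direction can be expected for this assay. Compound 4 is expected to show a step of a number no higher from compound 2 to compound 4 (the limit leaves the size open) that cannot be read beyond the scatter. Compound 4 is estimated at 26000 nM, within a range from 13000 nM to 60000 nM, most likely reported once more only as a limit.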

Compound 4, half-maximal effective concentration: > 26000 nM
Compound 4: only a limit was reported; the forecaster's own chance of this, stated with the estimate: 85%; the middle value sits exactly at the limit.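

In this assay, for the compounds shown here, compound 4 gives > 26000 nM, again a limit, so no step linking it to compound 1 or compound 2 can be read. The compounds shown leave open whether swapping the outer aryl group changes the read-out in this assay at all.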